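From a long amide chain to a short amine

The source may report more compounds than this note shows. Statements on the series, on what has been measured and on what is new or still open speak of the compounds shown alone.

Measured in a functional assay on A549 cells (Homo sapiens) for antiproliferative activity, read by sulforhodamine B assay, with a stated time of 48 h; on this read-out lower numbers stand for stronger inhibition and higher numbers for weaker inhibition:
- compound 1 `CCCCN(C)C(=O)CCCOc1cc(OC)c(OC)c2oc(-c3ccc(OC)cc3)c(O)c(=O)c12`: > 40000 nM (a limit)
- compound 2 `COc1ccc(-c2oc3c(OC)c(OC)cc(OCCCC(=O)N4CCN(C)CC4)c3c(=O)c2O)cc1`: > 40000 nM (a limit)
- compound 3 `CCCCN(C)C(=O)CCCCOc1cc(OC)c(OC)c2oc(-c3ccc(OC)cc3)c(O)c(=O)c12`: 16700 nM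

Among the measured compounds shown here, compound 3 gives the only number here, and the remainder is the limit of > 40000 nM in this assay, at which 2 of the 3 values shown sit. Compound 4 `COc1ccc(-c2oc3c(OC)c(OC)cc(OC(C)CN(C)C)c3c(=O)c2O)cc1` departs from it by this change: 1-((dimethylamino)methyl)ethyl in place of 4-(butyl(methyl)carbamoyl)butyl on an oxygen on an aromatic ring. Two measured steps end at compound 3 and touch the same chain: an at least 2.3-fold lower number from compound 1 to compound 3 (0.37 log units; beyond the scatter) and an at least 2.3-fold lower number from compound 2 to compound 3 (0.37 log units; beyond the scatter). The third, a step that the two limits leave unreadable from compound 1 to compound 2, cannot be read. Neither readable step covers this replacement, but both put the compounds with other chains on the higher side of compound 3. A small step towards a higher number is therefore expected in this assay. The expected step is a 1.8-fold higher number from compound 3 to compound 4 (0.25 log units; within the scatter). The estimate for compound 4 is 30000 nM, within an expected range of 8000 nM to 80000 nM.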

Compound 4, half-maximal inhibitory concentration: 6120 nM
For compound 4 the middle estimate is 4.9-fold (0.69 log units) above the measured one, outside the stated range (below it).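

In this assay, 1-((dimethylamino)methyl)ethyl on the oxygen gives a 2.7-fold lower number from compound 3 to compound 4 (0.44 log units; beyond the scatter), so among the compounds shown, a lower number needs neither the longest chain nor its amide. The same replacement gives an at least 6.5-fold lower number from compound 2 to compound 4 (0.81 log units; beyond the scatter) and an at least 6.5-fold lower number from compound 1 to compound 4 (0.81 log units; beyond the scatter). These two steps start from limits, not numbers: the limit of > 40000 nM in this assay, at which 2 of the 4 values shown sit.

The compounds shown leave open whether the step follows the dimethylamino group or the branching methyl. A straight two-carbon chain ending in dimethylamino, or a morpholine in place of the dimethylamino group, would bear on that.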